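Swapping a methyl for a hydroxy on the aniline ring

This account rests on a few compounds, and the source may have more. Where it says the series, first, only, none or still open, it means among the compounds named here.

Measured compounds:
- Compound 1, `Cc1ccc(Nc2nc(SCc3cn(CC(=O)NC(=O)Nc4ccccn4)nn3)nc(-c3ccc(C(C)C)cc3)c2C#N)cc1`: 3060 nM
- Compound 2, `Cc1ccccc1Nc1nc(SCc2cn(CC(=O)NC(=O)Nc3ccccn3)nn2)nc(-c2ccc(C(C)C)cc2)c1C#N`: 18600 nM

In a functional assay on B16-F10 cells (Mus musculus) for inhibition, read by MTT assay, with a stated time of 72 h (on this read-out lower numbers stand for stronger inhibition and higher numbers for weaker inhibition), compound 1 gives 3060 nM, and compound 2 gives 18600 nM. Going by the values given here, compound 2 thus has the highest number of the two measured compounds, meaning the weaker inhibition; its only neighbour is compound 1, and the step of a 6.1-fold higher number from compound 1 to compound 2 (0.78 log units; beyond the scatter) is beyond the scatter.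

Compound 3, `CC(C)c1ccc(-c2nc(SCc3cn(CC(=O)NC(=O)Nc4ccccn4)nn3)nc(Nc3ccccc3O)c2C#N)cc1`, has not yet been measured. It differs from compound 2 in one place: hydroxy in place of methyl on an aromatic carbon, in words hydroxy in place of methyl on an aromatic carbon. Among the compounds with values here, no measured step involves a hydroxy group; the only step available, a 6.1-fold higher number from compound 1 to compound 2 (0.78 log units; beyond the scatter), concerns where a methyl sits, not what replaces it, so it gives no direct guidance here. For compound 3 the expected step is therefore a 1.2-fold lower number from compound 2 to compound 3 (0.09 log units; within the scatter), no change beyond the scatter. Compound 3 is estimated at 15000 nM in this assay, within a range of 5000 nM to 45000 nM.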

Compound 3, half-maximal inhibitory concentration: 16100 nM
For compound 3 the middle estimate is 1.1-fold (0.03 log units) below the measured one; measured number inside the range.
By their numbers in this assay, from the lowest: compound 1; then compounds 3 and 2 (each within the scatter of the next).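

In this assay the change gives a 1.2-fold lower number from compound 2 to compound 3 (0.06 log units; within the scatter) for hydroxy in place of methyl, so the two groups cannot be told apart at this place, even though hydroxy carries a hydrogen-bond donor and acceptor and methyl carries neither. The distance to the 4-methylphenyl compound remains, with a 5.3-fold higher number from compound 1 to compound 3 (0.72 log units; beyond the scatter) for the 2-hydroxyphenyl group, so among these three compounds both 2-substituted rings give weaker inhibition than compound 1. No measurement at hand accounts for this result.

A hydroxy at the 4-position of the ring, which would show whether the group behaves differently there, remains an open case. So does the reading at the 2-position for a methoxy group, an amine or a fluorine atom.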